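Aryl variation on the triazolylmethyl lactam series

This account rests on a few compounds, and the source may have more. Where it says the series, first, only, none or still open, it means among the compounds named here.

Measured so far:
Compound 1, `Cc1ccc(-n2cc(CN3C(=O)C[C@@H]4CC[C@@]3(C)C4(C)C)nn2)cc1`: in a functional assay on PANC-1 cells (Homo sapiens) for inhibition, read by MTT assay, with a stated time of 24 h (a lower number here means a stronger inhibitor, a higher number a weaker inhibitor), compound 1 gives 270 nM.
Compound 2, `CC1(C)[C@H]2CC[C@]1(C)N(Cc1cn(-c3ccccc3)nn1)C(=O)C2`: in this assay compound 2 gives 160 nM.
Compound 3, `CC1(C)[C@H]2CC[C@]1(C)N(Cc1cn(-c3ccccc3Br)nn1)C(=O)C2`: in this assay compound 3 gives 280 nM.

All three numbers lie within the scatter of one another. Compound 1 sits closest to compound 3, with a 1.0-fold higher number from compound 1 to compound 3 (0.02 log units; within the scatter), and furthest from compound 2, with a 1.7-fold lower number from compound 1 to compound 2 (0.23 log units; within the scatter); the third step, a 1.8-fold higher number from compound 2 to compound 3 (0.24 log units; within the scatter), is likewise within the scatter. Across a 4-methylphenyl, a phenyl and a 2-bromophenyl on the triazole nitrogen, the shared core thus gives the same number within the usual spread.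

Compound 4, `COc1cccc(-n2cc(CN3C(=O)C[C@@H]4CC[C@@]3(C)C4(C)C)nn2)c1`, is the next point: 3-methoxyphenyl in place of 4-methylphenyl on an aromatic nitrogen. Going by the values given here, no measured pair carries a methoxy group, so the only guidance is that the two aryl changes from compound 1, a 1.7-fold lower number from compound 1 to compound 2 (0.23 log units; within the scatter) and a 1.0-fold higher number from compound 1 to compound 3 (0.02 log units; within the scatter), both stayed within the scatter. The expectation for this assay is therefore no step beyond the scatter, estimated as a 1.2-fold lower number from compound 1 to compound 4 (0.07 log units; within the scatter). Compound 4 is estimated at 230 nM, with a range from 100 nM to 550 nM.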

Compound 4, half-maximal inhibitory concentration: 860 nM
The estimate for compound 4 lay 3.7-fold (0.57 log units) below the measured number, outside the stated range (above it).
By their numbers in this assay, from the lowest: compounds 2, 1 and 3 (each within the scatter of the next); then compound 4.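

In this assay, going by these compounds alone, this aromatic nitrogen is no longer indifferent to its aryl group: 3-methoxyphenyl is the first group to give a step beyond the scatter, with a 3.2-fold higher number from compound 1 to compound 4 (0.50 log units; beyond the scatter) and with a 3.1-fold higher number from compound 3 to compound 4 (0.49 log units; beyond the scatter) in the direction of a weaker inhibitor. The largest step is the one that adds a methoxy group to the plain phenyl, with a 5.4-fold higher number from compound 2 to compound 4 (0.73 log units; beyond the scatter) on the shared core, so the tolerance seen among the first three aryl groups does not extend to this one. No evidence on hand explains the loss.

Within the data shown here, still open is whether the step follows the methoxy group itself or the ring position it occupies, as compound 4 is the only example. A 4-methoxyphenyl, a 3-methylphenyl or a 3-aminophenyl on the same nitrogen would separate these readings.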